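One Number and One Open Question on Stability

The source may report more compounds than this note shows. Statements on the series, on what has been measured and on what is new or still open speak of the compounds shown alone.

Compound 1 `CCc1ccc2oc(CSc3nnc(CNc4ccccc4)n3CC)nc2c1` gives "not determined" (no result reported)
Compound 2 `CCn1c(CNc2ccccc2)nnc1SCc1nc2cc(C(=O)C(C)C)ccc2o1` gives 42%
Compound 3 `CC/C(=N/OC)c1ccc2oc(CSc3nnc(CNc4ccccc4)n3CC)nc2c1` gives "not determined" (no result reported)

Going by the values given here, in an ADME assay on blood (Rattus norvegicus) for metabolic stability, with a stated time of 2 h (on this read-out higher numbers stand for a more stable compound and lower numbers for a less stable compound), compound 2 gives 42% as the only number in this small set. It therefore cannot be ranked against anything, since compound 1 and compound 3 have no reported result. Still to be measured in this assay is compound 4 `CC/C(=N/O)c1ccc2oc(CSc3nnc(CNc4ccccc4)n3CC)nc2c1` which differs from compound 2 in one place on the shared core. The isopropylcarbonyl on an aromatic carbon is replaced, and the change is a group of 5 heavy atoms (3 carbon, 1 nitrogen, 1 oxygen; no ring) in place of a group of 5 heavy atoms (4 carbon, 1 oxygen; no ring), on an aromatic carbon with the rest of the molecule untouched.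

Among the compounds with values here, no two measured compounds differ in a single place, so the data offer no earlier step against which to judge this change. With so little to go on, no step beyond the usual scatter is expected, in either direction. The expected shift is a number 3 percentage points higher from compound 2 to compound 4 (within the scatter) and this estimated step would stay within that scatter. The range must remain wide, as it rests only on the structural change and on compound 2 at 42% as a single reference. For compound 4 the estimated value is 45% with an expected range from 20% to 72% until the measurement is available.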

Compound 4, percent of the compound remaining: 100%
Compound 4: the middle estimate sits 55 percentage points below what was measured, outside the stated range (above it).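

In this assay, going by these compounds alone, a single aromatic carbon of the shared core proves decisive: replacing the isopropylcarbonyl with a group of the same heavy-atom count, which has one carbon fewer, one nitrogen and a hydrogen-bond donor that the isopropylcarbonyl lacks, produces a number 58 percentage points higher from compound 2 to compound 4 (beyond the scatter), a kind of comparison the earlier compounds could not offer since no two of them formed a measured pair. The change sits on a six-membered aromatic ring of carbon only, meta to a fused ring and para to a fused ring, and with the rest of the molecule untouched, the step belongs to this one replacement, although equal heavy-atom count and the same number of double bonds outside aromatic rings do not predict it. Nothing presented here establishes what lies behind the step.

The compounds shown leave open whether the hydrogen-bond donor, the nitrogen or the whole entering group carries the step. They also leave open how this assay would respond at this aromatic carbon to a different group, such as an amine, a carboxylic acid or a longer chain.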